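The compounds below may be only part of what the source reports. "The series", "measured", "known", "first", "only" and "open" are said of these compounds alone.

Working notes on the series: in a functional assay for antagonist activity at transient receptor potential cation channel subfamily V member 1 (Rattus norvegicus) (on this read-out higher numbers stand for weaker inhibition and lower numbers for stronger inhibition), compound 1 `Cc1cc(CNC(=O)CCc2ccc(C(C)(C)C)cc2)cc(C)c1NS(C)(=O)=O` gives 620 nM, while compound 2 `CC(C)(C)c1ccc(CCC(=S)NCc2ccc(NS(C)(=O)=O)c(F)c2)cc1` gives 40 nM. Within the data shown here, of the two numbers so far compound 2 stands lowest, and the gap to compound 1 is a large one, well beyond the scatter. Compound 1 and compound 2 differ in more than one place, so no single step can be read from them; the two values only show which of the pair inhibits more strongly in this assay.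

The next compound, compound 3 `CCc1cc(CNC(=S)CCc2ccc(C(C)(C)C)cc2)ccc1NS(C)(=O)=O`, is derived from compound 2 by a single change: ethyl in place of fluoro on an aromatic carbon. The thiocarbonyl and the methanesulfonamido group are kept. Among the measured compounds shown here, no measured pair tells how a group at this position affects the read-out, so the direction of this step is open; the working expectation is a small shift, if any, and one that may well stay within the scatter. The estimated step from compound 2 to compound 3 is a 2.0-fold higher number from compound 2 to compound 3 (0.30 log units; within the scatter). For compound 3 the expected value in this assay is 80 nM, with a range from 25 nM to 250 nM.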

Compound 3, half-maximal inhibitory concentration: 240 nM
Compound 3: middle estimate off by 3.0-fold (0.48 log units), on the low side; the range from low to high includes it.
By their numbers in this assay, from the lowest: compound 2; then compound 3; then compound 1.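

With the thiocarbonyl and the methanesulfonamido group held fixed, the change of fluoro to ethyl gives in this assay the series' first readable single step, a 6.0-fold higher number from compound 2 to compound 3 (0.78 log units; beyond the scatter), and this step lies beyond the scatter. The aromatic carbon ortho to a methanesulfonamido group is therefore not a neutral place in this pair, and the direction is towards weaker inhibition with ethyl than with fluoro. Nothing at hand gives a measured reason for this step.

One pair cannot show whether fluoro favours inhibition, ethyl disfavours it, or both, and a hydrogen, a chlorine, a methyl, a methoxy group or a longer chain such as propyl at this place would be needed to show where the read-out turns and whether it follows a trend. On these data alone, it also stays open whether the same change would give a step of similar size and direction with a carbonyl in place of the thiocarbonyl.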